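A few compounds are considered here, and "the series" means these few. Any claim that something is new, unique, unknown or untested is made for them only; others in the source may bear on it.

Three compounds have been measured in a functional assay on MKN-45 cells (Homo sapiens) for cytotoxicity, read by MTT assay, with a stated time of 72 h; on this read-out higher numbers stand for weaker inhibition and lower numbers for stronger inhibition:
Compound 1 `COc1cc2c(Oc3ccc(NC(=O)c4cc(-c5ccccc5C)ccn4)cc3F)ccnc2cc1OCCCN1CCN(C)CC1` gives 240 nM.
Compound 2 `COc1ccc(-c2ccnc(C(=O)Nc3ccc(Oc4ccnc5cc(OCCCN6CCN(C)CC6)c(OC)cc45)c(F)c3)c2)cc1` gives 250 nM.
Compound 3 `COc1cc2c(Oc3ccc(NC(=O)c4cc(-c5ccccc5C)ccn4)cc3F)ccnc2cc1OCCCN1CCCC1` gives 440 nM.

Compound 3 carries the highest of these three numbers, yet the step of a 1.8-fold higher number from compound 1 to compound 3 (0.26 log units; within the scatter) and the gap between the value of compound 2 and that of compound 3 both lie within the scatter, so the three compounds cannot be separated on the numbers shown. Compound 4 `COc1ccc(-c2ccnc(C(=O)Nc3ccc(Oc4ccnc5cc(OCCCN6CCCC6)c(OC)cc45)c(F)c3)c2)cc1` is the compound still to be measured. It differs from compound 3 in one place: 4-methoxyphenyl in place of 2-methylphenyl on an aromatic carbon. The same exchange has been seen once, on the pair that carries the 4-methylpiperazin-1-yl group instead of the pyrrolidin-1-yl group: there it gave a 1.0-fold higher number from compound 1 to compound 2 (0.02 log units; within the scatter). Within the data shown here, that step bears directly on the present one, and no other measured step does. The expected outcome in this assay is therefore no step beyond the scatter in either direction, estimated as no change at the digits printed from compound 3 to compound 4 (within the scatter). Compound 4 is accordingly expected to give about 440 nM, within a range from 200 nM to 950 nM.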

Compound 4, half-maximal inhibitory concentration: 150 nM
For compound 4 the middle estimate is 2.9-fold (0.47 log units) above the measured one; the measured number lies below the stated range.
By their numbers in this assay, from the lowest: compounds 4, 1, 2 and 3 (each within the scatter of the next, the first and the last beyond it).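

With the pyrrolidin-1-yl group on the chain, 4-methoxyphenyl in place of 2-methylphenyl gives a 2.9-fold lower number from compound 3 to compound 4 (0.47 log units; beyond the scatter) in this assay, a step that the pair carrying 4-methylpiperazin-1-yl did not show. What this exchange on the aromatic carbon does therefore depends on which amine the chain carries: the same change on two cores in this assay, a 1.0-fold higher number (0.02 log units; within the scatter) from compound 1 to compound 2 and a 2.9-fold lower number (0.47 log units; beyond the scatter) from compound 3 to compound 4, 3.1-fold (0.49 log units) apart, beyond the scatter of two such steps

Seen from the other side, pyrrolidin-1-yl in place of 4-methylpiperazin-1-yl gives a 1.7-fold lower number from compound 2 to compound 4 (0.22 log units; within the scatter), and although this step and its counterpart each stay within the scatter, they run in opposite directions: the same change on two cores in this assay, a 1.8-fold higher number (0.26 log units; within the scatter) from compound 1 to compound 3 and a 1.7-fold lower number (0.22 log units; within the scatter) from compound 2 to compound 4, 3.1-fold (0.49 log units) apart, beyond the scatter of two such steps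

Among these compounds, these four compounds hold only two aromatic groups and two amines, so it remains open whether this dependence extends to other groups. A morpholine or a dimethylamine on the chain, paired with each of the two aromatic groups, would test this.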